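Amide Tail Changes on a Shared Core in Breast Cancer Cells

The source may hold more compounds than are shown below. What is called first, only, known or untested is meant among the compounds shown, and "the series" means these compounds.

Three compounds sharing one core differ only in the group on the amide-type nitrogen. In a functional assay on MCF7 cells (Homo sapiens) for antiproliferative activity, read by MTT assay, with a stated time of 24 h (on this read-out higher numbers stand for weaker inhibition and lower numbers for stronger inhibition), compound 1 `CCN(CC)CCNC(=O)c1ccc(C(CC)(CC)c2ccc(OCS(=O)(=O)c3ccccc3)c(C)c2)n1CC` gives 4680 nM. Compound 2 `CCn1c(C(=O)NC2(CO)CC2)ccc1C(CC)(CC)c1ccc(OCS(=O)(=O)c2ccccc2)c(C)c1` gives 28800 nM in this assay, and compound 3 `CCn1c(C(=O)NCCCO)ccc1C(CC)(CC)c1ccc(OCS(=O)(=O)c2ccccc2)c(C)c1` gives 42000 nM. Compound 3 thus stands at the highest of the three numbers, its nearest neighbour being compound 2 and its furthest compound 1: a 9.0-fold higher number from compound 1 to compound 3 (0.95 log units; beyond the scatter), whereas a 1.5-fold higher number from compound 2 to compound 3 (0.16 log units; within the scatter).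

Compound 4 `CCn1c(C(=O)N[C@@H](CC(=O)O)C(=O)O)ccc1C(CC)(CC)c1ccc(OCS(=O)(=O)c2ccccc2)c(C)c1` is the next step from compound 3, with 1,2-dicarboxyethyl in place of 3-hydroxypropyl on an amide-type nitrogen. Going by the values given here, no measured step covers a change to a 1,2-dicarboxyethyl group, so the measured steps bear on it only loosely. They show that swapping the group on the amide-type nitrogen can move the number well beyond the scatter, as in a 6.2-fold higher number from compound 1 to compound 2 (0.79 log units; beyond the scatter), or hardly at all, as between compound 2 and compound 3. With compound 3 already at the weak end, a further move toward weaker inhibition or no change beyond the scatter seems the likelier outcome for compound 4, and the estimate is a 1.7-fold higher number from compound 3 to compound 4 (0.22 log units; within the scatter). Compound 4 is therefore expected to give about 70000 nM in this assay, within a range from 20000 nM to 250000 nM.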

Compound 4, half-maximal inhibitory concentration: > 50000 nM
Compound 4: no number, only a limit; the forecaster's own chance of this, stated with the estimate: 30%; the middle value does not contradict the limit.
By their numbers in this assay, from the lowest: compound 1; then compounds 2 and 3 (each within the scatter of the next). At a limit, above all of these: compound 4.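

The result for compound 4 in this assay is a limit and not a number: the limit of > 50000 nM in this assay, at which 1 of the 4 values shown sits. Even so, it extends the picture at this position, since the change from 2-(diethylamino)ethyl to 1,2-dicarboxyethyl on the amide-type nitrogen gives an at least 10-fold higher number from compound 1 to compound 4 (1.02 log units; beyond the scatter), a large step that puts this much larger group, like 3-hydroxypropyl and 1-(hydroxymethyl)cyclopropyl, on the weaker side of compound 1. Against those two tails the limit settles nothing, as the data give an at least 1.1-fold higher number from compound 3 to compound 4 (0.07 log units; that floor lies within the scatter) and an at least 1.7-fold higher number from compound 2 to compound 4 (0.23 log units; that floor lies within the scatter), so with both floors inside the scatter, compound 4 may or may not truly differ from either.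

The compounds shown leave open how far the true value of compound 4 lies past its limit, and whether a single carboxylic acid on a short chain would read like the 1,2-dicarboxyethyl group. They also leave open whether the stronger inhibition of compound 1 follows from the amine itself, which a primary amine or a dimethylamino group on the same chain could test, or from other features of its 2-(diethylamino)ethyl tail.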